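The compounds below may be only part of what the source reports. "The series", "measured", "known", "first", "only" and "open" are said of these compounds alone.

Of the compounds shown here, three sharing one core have been tested in a functional assay on MDA-MB-231 cells (Homo sapiens) for inhibition, read by MTT assay, with a stated time of 72 h; on this read-out lower numbers stand for stronger inhibition and higher numbers for weaker inhibition. Compound 1 `O=C(CSc1nc(Nc2ccccc2)c2ccccc2n1)Nc1cccc([N+](=O)[O-])c1` gives 33000 nM, compound 2 `O=C(CSc1nc(Nc2ccccc2)c2ccccc2n1)Nc1ccc(Cl)c(Cl)c1` gives 14500 nM, and compound 3 `C=CC(=O)Nc1cccc(NC(=O)CSc2nc(Nc3ccccc3Cl)c3ccccc3n2)c1` gives 12700 nM, the lowest number of the three, although its gap to compound 2 lies within the scatter. Among the measured compounds shown here, the only measured step, a 2.3-fold lower number from compound 1 to compound 2 (0.36 log units; beyond the scatter), concerns a group on the amide-type nitrogen. Compound 4 `C=CC(=O)Nc1cccc(NC(=O)CSc2nc(Nc3cc(OC)c(OC)c(OC)c3)c3ccccc3n2)c1` differs from compound 3 elsewhere: 3,4,5-trimethoxyphenyl in place of 2-chlorophenyl on a nitrogen on an aromatic ring. For the measured compounds named here, no measured step touches that nitrogen on the aromatic ring, so the change comes without guidance, and no shift beyond the scatter is expected. Compound 4 is therefore estimated at 12000 nM, with a range from 4000 nM to 40000 nM, which means an expected step of a 1.1-fold lower number from compound 3 to compound 4 (0.02 log units; within the scatter).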

Compound 4, half-maximal inhibitory concentration: > 50000 nM
Compound 4: only a limit was reported; the forecaster's own chance of this, stated with the estimate: 5%; middle value at least 4.1-fold (0.61 log units) from the limit.
By their numbers in this assay, from the lowest: compounds 3 and 2 (each within the scatter of the next); then compound 1. At a limit, above all of these: compound 4.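

Among the compounds shown here, on a nitrogen on an aromatic ring, the earlier compounds gave no sign of how much the attached group matters. In this assay, this position proves sensitive, with 3,4,5-trimethoxyphenyl in place of 2-chlorophenyl giving an at least 3.9-fold higher number from compound 3 to compound 4 (0.59 log units; beyond the scatter). The result for compound 4 is a limit and not a number, so the true size of this step is unknown: the limit of > 50000 nM in this assay, at which 1 of the 4 values shown sits.

Going by these compounds, whether losing the chlorine or gaining the methoxy groups drives the change stays open. So does how a smaller group on that ring, such as a single methoxy, a hydroxyl or an amine, would behave.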